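The source may report more compounds than this note shows. Statements on the series, on what has been measured and on what is new or still open speak of the compounds shown alone.

Measured in a physicochemical assay for solubility, read by nephelometry, measured as kinetic solubility, at pH 2.0; a higher number here means a more soluble compound, a lower number a less soluble compound:
Compound 1 `NCc1csc(NC(=O)c2ccccn2)n1`: > 100 ug/mL
Compound 2 `CC(C)(C)c1cc(C(=O)Nc2cccc(CN)c2)n(Cc2ccccc2)n1`: > 100 ug/mL

The entry for compound 1 is a limit of this assay and not a number. The entry for compound 2 is also a limit, so compound 2 stands only at > 100 ug/mL and has no exact value. Neither compound can be ranked against the other, as the record shows only (the limit of > 100 ug/mL in this assay, at which 2 of the 2 values shown sit).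

In compound 3 `CN(C)Cc1csc(NC(=O)c2cc(C(C)(C)C)nn2Cc2ccccc2)n1`, 4-((dimethylamino)methyl)-1,3-thiazol-2-yl stands in place of 3-(aminomethyl)phenyl on an amide-type nitrogen (4-((dimethylamino)methyl)-1,3-thiazol-2-yl in place of 3-(aminomethyl)phenyl on an amide-type nitrogen). Among the measured compounds shown here, no measured pair of compounds isolates this change, so the data give no step to carry over.

The expectation therefore rests on compound 2 at > 100 ug/mL, which is a limit. No step beyond the usual scatter is expected, and no firm direction is expected either. The estimated step is a number no higher from compound 2 to compound 3 (the limit leaves the size open). A further limit rather than a number is the more likely report. Compound 3 is estimated at 100 ug/mL, with an expected range from 60 ug/mL to 130 ug/mL.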

Compound 3, solubility: > 100 ug/mL
Compound 3 was reported as a limit; the forecaster's own chance of this, stated with the estimate: 70%; the middle value sits exactly at the limit.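

In this assay compound 3 gives > 100 ug/mL, which is a limit and not a number. No step from compound 2 to compound 3 can be read, because both entries are limits: the limit of > 100 ug/mL in this assay, at which 3 of the 3 values shown sit.

The compounds shown leave open how far their solubilities differ and what replacing 3-(aminomethyl)phenyl with 4-((dimethylamino)methyl)-1,3-thiazol-2-yl changes.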